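Same Swap on a Second Core, Checked for Cytotoxicity

This account rests on a few compounds, and the source may have more. Where it says the series, first, only, none or still open, it means among the compounds named here.

Compound 1 `NC(=S)c1ccc(OC(=O)c2cccnc2)cc1` and compound 2 `O=C(Oc1ccc(-c2cc(=S)ss2)cc1)c1cccnc1` were tested in an ADME assay on RAW264.7 cells (Mus musculus) for cytotoxicity, read by MTT assay, with a stated time of 48 h; on this read-out lower numbers stand for stronger inhibition and higher numbers for weaker inhibition. Compound 1 reaches only a limit of the assay, > 800000 nM. Compound 2 likewise gives only a limit, > 800000 nM. The two differ by a group of 6 heavy atoms (3 carbon, 3 sulfur; one five-membered aromatic ring with 2 hetero atoms) in place of a group of 3 heavy atoms (1 carbon, 1 nitrogen, 1 sulfur; no ring), on an aromatic carbon, and the step that the two limits leave unreadable from compound 1 to compound 2. Compound 3 `CC(C)(Oc1ccc(Cl)cc1)C(=O)Oc1ccc(C(N)=S)cc1` has a different core; how the two cores differ is not broken down here. In this assay compound 3 also gives only a limit, > 800000 nM. Compound 4 `CC(C)(Oc1ccc(Cl)cc1)C(=O)Oc1ccc(-c2cc(=S)ss2)cc1` has not yet been measured. It differs from compound 3 by a group of 6 heavy atoms (3 carbon, 3 sulfur; one five-membered aromatic ring with 2 hetero atoms) in place of a group of 3 heavy atoms (1 carbon, 1 nitrogen, 1 sulfur; no ring), on an aromatic carbon, the same kind of change as between compound 1 and compound 2, here para to a large group. The expectation for it rests on the fact that every measured value sits at the limit of > 800000 nM in this assay, at which 3 of the 3 values shown sit. The step of a number no higher from compound 3 to compound 4 (the limit leaves the size open) is expected to stay unreadable. Compound 4 is estimated at 800000 nM, most likely once more a limit, within 300000 nM to 2000000 nM.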

Compound 4, half-maximal inhibitory concentration: > 800000 nM
Compound 4: only a limit was reported; the forecaster's own chance of this, stated with the estimate: 85%; the middle value sits exactly at the limit.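

No step can be read between compound 3 and compound 4, since both give only a limit. The compounds shown leave open how the two groups compare and what actual half-maximal inhibitory concentration any of the four compounds has in this assay.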